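A few compounds are considered here, and "the series" means these few. Any claim that something is new, unique, unknown or untested is made for them only; others in the source may bear on it.

Of the compounds shown here, three built on a shared core have been measured in a functional assay on NUGC-3 cells (Homo sapiens) for cytotoxicity, read by sulforhodamine B assay, with a stated time of 72 h; a higher number here means a weaker inhibitor of growth, a lower number a stronger inhibitor of growth. Compound 1, `COc1ccc(NC(=O)C2CCc3ccccc3N2)cc1`, gives 51900 nM. Compound 3, `O=C(Nc1ccccc1O)C1CCc2ccccc2N1C(=O)c1ccccc1`, gives 3780 nM. Compound 2, `O=C(Nc1cc(C(F)(F)F)cc(C(F)(F)F)c1)C1CCc2ccccc2N1C(=O)c1cccc(Cl)c1`, gives 560 nM, the lowest of the three numbers; its gaps to compound 3 and to compound 1 both lie beyond the scatter, so compound 2 is the strongest growth inhibitor of the set. Compound 4, `CCCCCCCCC(=O)N1c2ccccc2CCC1C(=O)Nc1cc(C(F)(F)F)cc(C(F)(F)F)c1`, differs from compound 2 in one place: octyl in place of 3-chlorophenyl on a carbonyl carbon. Going by the values given here, no measured pair shows this kind of change, so nothing here says how swapping an aromatic ring for a chain affects growth inhibition. A modest step towards weaker inhibition is expected, a 2.7-fold higher number from compound 2 to compound 4 (0.43 log units; beyond the scatter), though a step within the scatter remains possible. Compound 4 is estimated at 1500 nM, with a range from 400 nM to 6000 nM.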

Compound 4, concentration for 50% growth inhibition: 2230 nM
Beside the measured number, compound 4's estimate is 1.5-fold (0.17 log units) below it; measured number inside the range.
By their numbers in this assay, from the lowest: compound 2; then compounds 4 and 3 (each within the scatter of the next); then compound 1.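

In this assay the swap of 3-chlorophenyl for octyl on this carbonyl carbon gives a 4.0-fold higher number from compound 2 to compound 4 (0.60 log units; beyond the scatter) as a modest step. Compound 4 still inhibits growth at 2230 nM without any ring in this group, so an aromatic ring here is not required for activity, though the 3-chlorophenyl of compound 2 does better. No measured evidence explains this step. The compounds shown leave open how a shorter chain such as butyl would compare with octyl. They also leave open whether an unsubstituted phenyl or a chain ending in an amine would fare better or worse.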